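Taking the nitrile off compound 1

The source may report more compounds than this note shows. Statements on the series, on what has been measured and on what is new or still open speak of the compounds shown alone.

Compound 1 `CNC(=O)c1cc(Oc2ccc(C3=NNC(c4ccc(C#N)cc4)C3)cc2)ccn1`: 17400 nM
Compound 2 `CNC(=O)c1cc(Oc2ccc(C3=NNC(c4ccc(OC)cc4)C3)cc2)ccn1`: 13100 nM

Going by the values given here, in a functional assay on A549 cells (Homo sapiens) for cytotoxicity, read by MTT assay, with a stated time of 72 h (a lower number here means a stronger inhibitor, a higher number a weaker inhibitor), compound 1 stands within the scatter of its only measured neighbour, compound 2. The step between them reads a 1.3-fold lower number from compound 1 to compound 2 (0.12 log units; within the scatter), so these two numbers give no ranking.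

The next compound to be measured is compound 3 `CNC(=O)c1cc(Oc2ccc(C3=NNC(c4ccccc4)C3)cc2)ccn1`, which keeps the core of compound 1 and carries hydrogen in place of cyano on an aromatic carbon, para to a large group: hydrogen in place of cyano on an aromatic carbon. Among the compounds with values here, only one measured step bears on this change, since it replaces the same cyano group at the same place, this time with methoxy. Within the data shown here, that step is small, but it is only indirect evidence, as no compound with hydrogen at this place has a measured value yet. Given a 1.3-fold lower number from compound 1 to compound 2 (0.12 log units; within the scatter), no step beyond the scatter is expected in this assay, and no direction can be favoured. The expected change is a 1.2-fold lower number from compound 1 to compound 3 (0.06 log units; within the scatter). The estimate for compound 3 is an expected 15000 nM, with a range from 7000 nM to 32000 nM.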

Compound 3, half-maximal inhibitory concentration: 8600 nM
For compound 3 the middle estimate is 1.7-fold (0.24 log units) above the measured one; measured number inside the range.
By their numbers in this assay, from the lowest: compounds 3, 2 and 1 (each within the scatter of the next, the first and the last beyond it).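

With hydrogen in place of cyano on this aromatic carbon, the series gains its first pair that can be ranked in this assay (a 2.0-fold lower number from compound 1 to compound 3 (0.31 log units; beyond the scatter)), a modest step that makes compound 3 the stronger inhibitor of those two. The earlier exchange of the same cyano group for methoxy gave no ranking, so the 4-cyanophenyl to phenyl change shows that this position can register a difference, though only a small one. Hydrogen and methoxy at this place remain unresolved (a 1.5-fold lower number from compound 2 to compound 3 (0.18 log units; within the scatter)), and compound 2 lies within the scatter of both compound 1 and compound 3, so the three compounds do not form a firm order.

These compounds leave open whether an amine, a carboxylic acid or a chlorine atom at this place would move the number further than the nitrile-to-hydrogen exchange did, or would leave it within the scatter of compound 3. Nothing presented here accounts for the step from the nitrile to hydrogen.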